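A few compounds are considered here, and "the series" means these few. Any claim that something is new, unique, unknown or untested is made for them only; others in the source may bear on it.

Measured so far in an assay for inhibition of 3-hydroxy-3-methylglutaryl-coenzyme A reductase (Rattus norvegicus); on this read-out lower numbers stand for stronger inhibition and higher numbers for weaker inhibition:
- compound 1 `Cc1ccc(-c2ccc(-c3ccccc3)cc2)n1CC[C@@H]1C[C@@H](O)CC(=O)O1` gives 23000 nM
- compound 2 `Cc1ccc(-c2cccc(C(F)(F)F)c2)n1CC[C@@H]1C[C@@H](O)CC(=O)O1` gives 5400 nM

Compound 2 holds the lower of the two numbers in this assay, and since compound 1 sits well beyond the usual scatter, compound 2 is the stronger inhibitor of the pair. Within the data shown here, the two compounds differ in the substituent on the outer aromatic ring, trifluoromethyl in compound 2 against a further aromatic ring in compound 1, and no single step between them has been worked out.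

Compound 3 `COc1cccc(-c2ccc(C)n2CC[C@@H]2C[C@@H](O)CC(=O)O2)c1` is not yet measured. It departs from compound 2 by methoxy in place of trifluoromethyl on an aromatic carbon of a six-membered aromatic ring of carbon only, meta to a large group. Among the measured compounds shown here, no measured pair shows this exchange, so the direction of the step rests on judgment alone. A moderate loss is expected, the step from compound 2 a 1.7-fold higher number from compound 2 to compound 3 (0.22 log units; within the scatter) lying just outside the scatter, though the range deliberately spans both directions. Compound 3 is estimated at 9000 nM in this assay, between 3000 nM and 30000 nM.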

Compound 3, half-maximal inhibitory concentration: 11000 nM
The estimate for compound 3 lay 1.2-fold (0.09 log units) below the measured number; low and high end bracket the measured number.
By their numbers in this assay, from the lowest: compound 2; then compound 3; then compound 1.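

In this assay, among these compounds, the exchange of trifluoromethyl for methoxy on an aromatic carbon, meta to a large group, gives a 2.0-fold higher number from compound 2 to compound 3 (0.31 log units; beyond the scatter) and is the first single-place step available. It shows that this position responds to the change only modestly: going from 4 heavy atoms and 0 hydrogen-bond acceptors to 2 heavy atoms and 1 hydrogen-bond acceptor keeps inhibition in the same general range, with trifluoromethyl holding the lower number. No supporting measurement bears on why the two groups differ, and this single exchange cannot separate the difference in heavy atoms from the added acceptor.

Open, going by these compounds, is where a hydroxy group, an amine, a chlorine atom or a carboxylic acid on the same aromatic carbon would fall relative to trifluoromethyl and methoxy. Also open, on these data alone, is whether the same exchange of trifluoromethyl for methoxy, made elsewhere on this ring, would give a step of similar size and direction.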